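Swapping the Ring on a Thiocarbonyl Carbon

This account rests on a few compounds, and the source may have more. Where it says the series, first, only, none or still open, it means among the compounds named here.

In a functional assay on MCF7 cells (Homo sapiens) for inhibition, read by MTT assay, with stated times of 18 h and 4 h (on this read-out lower numbers stand for stronger inhibition and higher numbers for weaker inhibition), compound 3 (`CCCCCCOP(=O)(O)OCCSC(=S)N1CCCCC1`) gives 62000 nM. Compound 1 (`CCCCCCOP(=O)(O)OCCSC(=S)N1CCCCCC1`) gives 55000 nM, and compound 2 (`CCCCCCOP(=O)(O)OCCSC(=S)N1CCCC1`) gives 100000 nM, so compound 3 stands among values that repeated measurements could not separate. Compound 4 (`CCCCCCOP(=O)(O)OCCSC(=S)N1CCN(C)CC1`) has 4-methylpiperazin-1-yl in place of piperidin-1-yl on a thiocarbonyl carbon. The ring swaps already measured, a 1.1-fold higher number from compound 1 to compound 3 (0.05 log units; within the scatter), a 1.6-fold lower number from compound 2 to compound 3 (0.21 log units; within the scatter) and a 1.8-fold higher number from compound 1 to compound 2 (0.26 log units; within the scatter), all lie within the scatter. None of them brings in 4-methylpiperazin-1-yl, so they are only a loose guide. No change beyond the scatter is expected in this assay. The expected step is a 1.1-fold higher number from compound 3 to compound 4 (0.05 log units; within the scatter). For compound 4 the estimate is 70000 nM, with an expected range from 32000 nM to 150000 nM.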

Compound 4, half-maximal inhibitory concentration: 58000 nM
Compound 4: the middle estimate sits 1.2-fold (0.08 log units) above what was measured; low and high end bracket the measured number.
By their numbers in this assay, from the lowest: compounds 1, 4, 3 and 2 (each within the scatter of the next).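

Within the data shown here, the ring in compound 4 is the first here to offer a hydrogen-bond acceptor on the thiocarbonyl carbon, yet in this assay the steps remain within the scatter: a 1.1-fold lower number from compound 3 to compound 4 (0.03 log units; within the scatter) and a 1.7-fold lower number from compound 2 to compound 4 (0.24 log units; within the scatter) and also a 1.1-fold higher number from compound 1 to compound 4 (0.02 log units; within the scatter). These four rings therefore cannot be told apart at this position. No available evidence accounts for this result. Still open, from the compounds shown here alone, is whether a morpholin-4-yl ring or an open-chain diethylamino group on the thiocarbonyl carbon would give a number beyond the scatter.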